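Toxicity notes on an aryloxyacetamide series: compound 3 to compound 4

The compounds below may be only part of what the source reports. "The series", "measured", "known", "first", "only" and "open" are said of these compounds alone.

Measured so far:
Compound 1 `Cc1cc(C)cc(NC(=O)COc2cc(C)nc3ccccc23)c1` in a toxicity assay on HepG2 cells (Homo sapiens) for inhibition, read by CellTiter-Glo, with a stated time of 48 h (on this read-out lower numbers stand for stronger inhibition and higher numbers for weaker inhibition), gives > 100000 nM, a limit of the assay.
Compound 2 `COc1ccc2nc(C)cc(NC(=O)C(=O)Nc3cc(C)cc(C)c3)c2c1` in this assay gives > 100000 nM, also a limit.
Compound 3 `COc1ccc2nc(C)cc(OCC(=O)Nc3cc(C)ccc3OC)c2c1` in this assay gives > 100000 nM, again a limit.

Compound 3 therefore stands at no number at all but at the edge of what this assay reports, and it is not alone there because of the limit of > 100000 nM in this assay, at which 3 of the 3 values shown sit. Nothing in the set so far separates one compound from another; all three sit at the same limit, so no ordering among them can be drawn.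

Compound 4 `COc1ccc2nc(C)cc(OCC(=O)Nc3nccs3)c2c1` is the next entry. It differs from compound 3 in one place (1,3-thiazol-2-yl in place of 2-methoxy-5-methylphenyl on an amide-type nitrogen).

Among the measured compounds shown here, with every value so far at the limit, no step of any size has been observed in this assay, and the expectation for compound 4 is that the step of a number no higher from compound 3 to compound 4 (the limit leaves the size open) stays within the scatter. Compound 4 is accordingly estimated at 100000 nM, with a range from 50000 nM to 200000 nM, and most likely only a limit will again be reported.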

Compound 4, half-maximal inhibitory concentration: > 100000 nM
Compound 4: only a limit was reported; the forecaster's own chance of this, stated with the estimate: 80%; the middle value sits exactly at the limit.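

No step can be read from compound 3 to compound 4 in this assay, as both compounds are reported only as limits: the limit of > 100000 nM in this assay, at which 4 of the 4 values shown sit. The compounds shown leave open whether any change on the amide-type nitrogen would bring a value within the reported range of this assay.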